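The source may report more compounds than this note shows. Statements on the series, on what has been measured and on what is new or still open speak of the compounds shown alone.

Compound 1 `O=C(Nc1cccc(-n2cc(-c3ccncc3)c(-c3ccc(Cl)c(O)c3)n2)c1)Nc1cccc(C(F)(F)F)c1` was tested in a functional assay on KM12 cells (Homo sapiens) for inhibition, read by sulforhodamine B assay, with a stated time of 48 h (on this read-out lower numbers stand for stronger inhibition of growth and higher numbers for weaker inhibition of growth), where compound 1 gives 1330 nM. That is the highest of the two numbers recorded so far. Compound 2 `COc1cc(-c2nn(-c3cccc(NC(=O)Nc4cc(C(F)(F)F)cc(C(F)(F)F)c4)c3)cc2-c2ccncc2)ccc1Cl` gives 531 nM in this assay, a lower number beyond the usual scatter; but compound 2 differs from compound 1 in more than one place, so the two values can only be set side by side and tell nothing about any single change. Compound 3 `O=C(Nc1cccc(-n2cc(-c3ccncc3)c(-c3ccc(Cl)c(O)c3)n2)c1)Nc1ccc(Cl)c(Cl)c1` has not yet been measured. It differs from compound 1 in one place: 3,4-dichlorophenyl in place of 3-(trifluoromethyl)phenyl on an amide-type nitrogen. Within the data shown here, no pair of measured compounds shows this change, so the expectation rests on compound 1 alone. The change is expected to bring only a small step, likely within the scatter: a 1.4-fold lower number from compound 1 to compound 3 (0.15 log units; within the scatter). For compound 3 the estimated value in this assay is 950 nM, with a range from 320 nM to 2800 nM.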

Compound 3, concentration for 50% growth inhibition: 1010 nM
Beside the measured number, compound 3's estimate is 1.1-fold (0.03 log units) below it; low and high end bracket the measured number.
By their numbers in this assay, from the lowest: compounds 2, 3 and 1 (each within the scatter of the next, the first and the last beyond it).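

On the amide-type nitrogen, 3,4-dichlorophenyl in place of 3-(trifluoromethyl)phenyl gives, in this assay, a 1.3-fold lower number from compound 1 to compound 3 (0.12 log units; within the scatter). This is the first change in a single place among these compounds, and it shows that one substituted phenyl group can replace the other at this position with no difference in growth inhibition that stands clear of the scatter. No measurement at hand explains why the two groups give such similar numbers.

As far as these compounds go, both groups are substituted phenyl rings, so the effect of a different kind of group on this nitrogen, such as a cyclohexyl ring, a carboxylic acid or a longer alkyl chain, remains open. Also open, from the compounds shown here alone, is whether the same swap would give so small a step on the core of compound 2.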